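Working notes: swapping methoxy for chloro on compound 2

This account rests on a few compounds, and the source may have more. Where it says the series, first, only, none or still open, it means among the compounds named here.

Compound 1 `COc1cc(OC)cc([C@@H]2C(=O)c3cc(OC)cc(OC)c3[C@H]2c2ccc(F)cc2)c1` gives 44800 nM
Compound 2 `COc1ccc(/C=C2/c3cc(OC)cc(OC)c3[C@@H](c3ccc(OC)cc3)[C@@H]2c2cc(OC)cc(OC)c2)cc1` gives 6260 nM

Both values come from a functional assay on RAW264.7 cells (Mus musculus) for inhibition, with stated times of 2 h and 24 h; a higher number here means a weaker inhibitor, a lower number a stronger inhibitor. Compound 2 has the lower of the two numbers, and its gap to compound 1 lies beyond the scatter. Compound 3 `COc1ccc([C@@H]2c3c(OC)cc(OC)cc3/C(=C/c3ccc(Cl)cc3)[C@H]2c2cc(OC)cc(OC)c2)cc1` carries chloro in place of methoxy on an aromatic carbon, para to a large group, reading as 4-methoxyphenyl to 4-chlorophenyl (chloro in place of methoxy on an aromatic carbon). Going by the values given here, no measured pair shows this change alone, so no direction is favoured. The expected step of a 1.0-fold lower number from compound 2 to compound 3 (0.02 log units; within the scatter) stays within the scatter. Compound 3 is estimated at 6000 nM (2500 nM to 16000 nM) in this assay.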

Compound 3, half-maximal inhibitory concentration: > 200000 nM
Compound 3: only a limit was reported; the forecaster's own chance of this, stated with the estimate: 10%; middle value at least 33-fold (1.52 log units) away from the limit.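

In this assay, this position proves sensitive to the group it carries: chloro in place of methoxy on an aromatic carbon, para to a large group, gives an at least 31-fold higher number from compound 2 to compound 3 (1.50 log units; beyond the scatter). Going by these compounds alone, this is the first comparison that differs in one place, and the step is large. For compound 3 the reading is a limit of the assay and not a number: the limit of > 200000 nM in this assay, at which 1 of the 3 values shown sits.

On these data alone, whether a hydroxyl or an amine at this position would hold the activity of compound 2 stays open. So does whether the same change on the remaining 4-methoxyphenyl group of compound 3 would act alike.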